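This account rests on a few compounds, and the source may have more. Where it says the series, first, only, none or still open, it means among the compounds named here.

Measured so far in a functional assay on 143B cells (Homo sapiens) for inhibition, read by CCK-8 assay, with a stated time of 72 h, tested at 1 uM; a higher number here means more inhibition at the concentration tested (going by the name of the read-out), a lower number less inhibition:

- compound 1, `COc1ccc(OC)c(N2C(=O)CSC2c2cccc(C(=O)NCCCCc3ccccc3)c2)c1`, gives 2%
- compound 2, `COc1ccc(F)cc1N1C(=O)CSC1c1cccc(C(=O)NCCCCc2ccccc2)c1`, gives 62%
- compound 3, `CC(F)(F)c1cccc(N2C(=O)CSC2c2cccc(C(=O)NCCCCc3ccccc3)c2)c1`, gives 1%

Compound 3 stands lowest of the three numbers, but its nearest neighbour is compound 1 at a number 1 percentage points lower from compound 1 to compound 3 (within the scatter), so the two cannot be told apart; only compound 2 stands clearly away, the step being a number 61 percentage points lower from compound 2 to compound 3 (beyond the scatter).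

Compound 4, `COc1c(F)cccc1N1C(=O)CSC1c1cccc(C(=O)NCCCCc2ccccc2)c1`, is not yet measured. Its change from compound 3 is a group of 9 heavy atoms (7 carbon, 1 oxygen, 1 fluorine; one six-membered aromatic ring of carbon only) in place of a group of 10 heavy atoms (8 carbon, 2 fluorine; one six-membered aromatic ring of carbon only), on an amide-type nitrogen in a ring.

Going by the values given here, two measured steps bear on this. The closest is the reverse of the step from compound 2 to compound 3, a number 61 percentage points lower from compound 2 to compound 3 (beyond the scatter), where a ring carrying one methoxy and one fluoro replaces the ring carrying the difluoroethyl group, though the fluoro in compound 4 sits at a different position of the ring. The step of a number 60 percentage points higher from compound 1 to compound 2 (beyond the scatter) shows that the placement of substituents on that ring matters greatly. Compound 4 is therefore expected to rise from compound 3 by a number 34 percentage points higher from compound 3 to compound 4 (beyond the scatter) in this assay, with wide uncertainty. The expected value for compound 4 is 35%, within 3% to 70%.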

Compound 4, a percentage reported as inhibition, at one concentration (the size of the read-out at that concentration, not a potency): 5%
The estimate for compound 4 lay 30 percentage points above the measured number; the measured number falls inside the stated range.
By their numbers in this assay, from the lowest: compounds 3, 1 and 4 (each within the scatter of the next); then compound 2.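

In this assay the place of the fluoro alone decides the outcome: 3-fluoro-2-methoxyphenyl in place of 5-fluoro-2-methoxyphenyl gives (a number 57 percentage points lower from compound 2 to compound 4 (beyond the scatter)), so having a methoxy and a fluoro on this ring is not enough to keep the inhibition of compound 2. The new ring cannot be told apart from the ring of compound 3 (a number 4 percentage points higher from compound 3 to compound 4 (within the scatter)) or from 2,5-dimethoxyphenyl (a number 3 percentage points higher from compound 1 to compound 4 (within the scatter)). Of the four rings on the amide-type nitrogen, only the 5-fluoro-2-methoxyphenyl ring stands clear of the others.

On these data alone, whether a chlorine atom or a nitrile in place of the fluoro in that ring would hold the inhibition of compound 2 stays open. Nothing available explains why the place of the fluoro counts for so much.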